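The source may report more compounds than this note shows. Statements on the series, on what has been measured and on what is new or still open speak of the compounds shown alone.

Measured in a physicochemical assay for lipophilicity; on this read-out higher numbers stand for higher lipophilicity and lower numbers for lower lipophilicity:
Compound 1 `CS(=O)(=O)c1ccc2sc(NC(=O)NC(=O)c3ccccc3Cl)nc2c1` gives 2.8.
Compound 2 `CN1CCN(CCCS(=O)(=O)c2ccc3nc(NC(=O)NC(=O)c4cc(-n5cccc5)ccc4Cl)sc3c2)CC1` gives 2.6.
Compound 3 `Cc1ccnn1-c1ccc(Cl)c(C(=O)NC(=O)Nc2nc3ccc(S(=O)(=O)C4CCN(C)CC4)cc3s2)c1` gives 2.6.

Compound 2 stands level with compound 3 at the digits given, and the two together hold the lowest of the three numbers. Its nearest neighbour is compound 3, with no change at these digits, within the scatter; its furthest is compound 1, whose number lies higher but still within the scatter. Among the compounds with values here, no two of the measured compounds differ in only one place, so no single measured step is available to set a scale, and all three numbers sit close together in this assay.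

Compound 4 `CCc1ccc(Cl)c(C(=O)NC(=O)Nc2nc3ccc(S(=O)(=O)CCCN4CCN(C)CC4)cc3s2)c1` has not yet been measured in this assay. It differs from compound 2 by ethyl in place of 1H-pyrrol-1-yl on an aromatic carbon. The change is confined to this one position; the rest of the molecule, including the sulfonyl-linked chain and the shared core, is unchanged between compound 2 and compound 4.

Within the data shown here, with no measured step between two compounds differing in one place, the expectation rests on how tightly the three measured numbers cluster. The step of a number 0.10 log units higher from compound 2 to compound 4 (within the scatter) is expected to be small, leaning slightly upward if at all, and not beyond the scatter. Compound 4 is therefore expected to give 2.7, with a likely range from 2.3 to 3.1.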

Compound 4, distribution coefficient: 2.9
Compound 4: the middle estimate sits 0.20 log units below what was measured; measured number inside the range.
By their numbers in this assay, from the lowest: compounds 2, 3, 1 and 4 (each within the scatter of the next).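

In this assay, this position, para to a chloro group on a six-membered aromatic ring of carbon only, now has its first step between compounds that differ in one place: ethyl in place of 1H-pyrrol-1-yl gives a number 0.30 log units higher from compound 2 to compound 4 (within the scatter). The exchange removes the five-membered aromatic ring and its hydrogen-bond acceptor, and what enters has no ring, yet the two compounds remain within the scatter of each other, so this single pair shows no clear separation between these two groups on this read-out. No independent measurement shown here bears on the origin of the step, so it stands as an observation without an explanation.

Still open, from the compounds shown here alone, is whether an amine, a carboxylic acid or a longer alkyl chain at this same position would also stay within the scatter of compound 2, or would produce a step beyond it. Also open, going by these compounds, is whether the exchange of 1H-pyrrol-1-yl for ethyl gives a similar step when the sulfonyl-linked chain of compound 2 is replaced by another group.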